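Ester series: phenoxy in place of phenyl, expected effect

The compounds below may be only part of what the source reports. "The series", "measured", "known", "first", "only" and "open" are said of these compounds alone.

Measured so far:
compound 1 `CCCOC(=O)/C=C/c1ccc(C(C)C)cc1` in a functional assay on the whole organism for inhibition, with Brassica rapa subsp. chinensis as the target, with a stated time of 3 days, tested at 100 ppm (a lower number here means less inhibition of growth, a higher number more inhibition of growth at the concentration tested), gives 5%
compound 2 `O=C(/C=C/c1ccc(Cl)cc1)OCCOc1ccccc1` in this assay gives 0%
compound 3 `CC(C)c1ccc(/C=C/C(=O)OCCc2ccccc2)cc1` in this assay gives 0%

Compound 3 stands level with compound 2 at the digits shown, and the two together are the lowest of the three numbers. The furthest value from compound 3 is that of compound 1, and even that gap lies within the scatter. All three esters sit at the low end of the read-out.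

Compound 4 `CC(C)c1ccc(/C=C/C(=O)OCCOc2ccccc2)cc1` is the next one to be measured in this assay. Relative to compound 3 the change is phenoxy in place of phenyl on a saturated chain carbon, two bonds along the chain from an oxygen next to a carbonyl group.

Among the compounds with values here, only one measured step touches this position on the chain: a number 5 percentage points lower from compound 1 to compound 3 (within the scatter), a change within the scatter. Within the data shown here, compound 2 already carries a phenoxy group on its chain and gives 0% in this assay; no step from compound 2 to compound 4 is computed, so its value only shows that a phenoxy-bearing ester also sits at the bottom of the range. The step of a number 2 percentage points higher from compound 3 to compound 4 (within the scatter) is therefore expected to be none beyond the scatter. Compound 4 is estimated to give 2%, with a range from 0% to 15%.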

Compound 4, percent growth inhibition at one concentration: 0%
Compound 4: middle estimate off by 2 percentage points, on the high side, and the stated range covers the measured number.
By their numbers in this assay, from the lowest: compounds 2, 3, 4 and 1 (each within the scatter of the next).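

Phenoxy in place of phenyl on a saturated chain carbon, two bonds along the chain from an oxygen next to a carbonyl group, gives no change at the digits printed from compound 3 to compound 4 (within the scatter) in this assay and so reads this exchange directly with the isopropyl group held constant. Isopropyl in place of chloro on an aromatic carbon gives no change at the digits printed from compound 2 to compound 4 (within the scatter) with phenoxy held on the chain, while phenoxy in place of methyl gives a number 5 percentage points lower from compound 1 to compound 4 (within the scatter) with isopropyl held, so no step among these compounds goes beyond the scatter. No available data bear on the reason for this flat picture.

All of these esters sit at the low end of the read-out, which leaves little room to tell one change from another. On these data alone, whether an amine or a carboxylic acid at the chain end, or a longer chain before the phenoxy group, would raise growth inhibition remains open.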